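Extending the amine of compound 2 with a 4-methoxybenzyl group

The compounds below may be only part of what the source reports. "The series", "measured", "known", "first", "only" and "open" are said of these compounds alone.

Compound 1 `Nc1nc(N2CCN(C3CCCC3)CC2)c2ncn(CCCN3CCCC3)c2n1` and compound 2 `CCN1CCN(CCCn2cnc3c(N4CCN(CC)CC4)nc(N)nc32)CC1` share one core and differ in the groups attached to it. In an assay on HEK293 cells for antagonist activity at Toll-like receptor 9 (Homo sapiens), read by spectrophotometry (on this read-out lower numbers stand for stronger inhibition and higher numbers for weaker inhibition), compound 1 gives 120 nM, while compound 2 gives 260 nM, the higher of the two numbers, and the gap between compound 2 and compound 1 lies beyond the scatter. Compound 3 `CCN1CCN(CCCn2cnc3c(N4CCN(CC)CC4)nc(NCc4ccc(OC)cc4)nc32)CC1` carries 4-methoxybenzyl in place of hydrogen on a nitrogen on an aromatic ring. Among the compounds with values here, no measured pair shows this change, so the step from compound 2 to compound 3 is expected to be small, a 1.4-fold lower number from compound 2 to compound 3 (0.16 log units; within the scatter), within or near the scatter. In this assay compound 3 is expected to give about 180 nM, between 50 nM and 700 nM.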

Compound 3, half-maximal inhibitory concentration: 200 nM
Beside the measured number, compound 3's estimate is 1.1-fold (0.05 log units) below it; measured number inside the range.
By their numbers in this assay, from the lowest: compounds 1, 3 and 2 (each within the scatter of the next, the first and the last beyond it).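

In this assay, putting 4-methoxybenzyl in place of hydrogen on this nitrogen gives a 1.3-fold lower number from compound 2 to compound 3 (0.11 log units; within the scatter), so this amino group of compound 2 accepts a group of this size with no change beyond the scatter. The earlier compounds shown here both carry the plain amino group here, so they could not show this. Nothing at hand explains the result. From the compounds shown here alone, whether an unsubstituted benzyl, a methyl or an acetyl group on this nitrogen would read the same stays open, as does whether the methoxy group matters at all.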